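Isopentyl for propyl at the cytotoxicity limit

The source may hold more compounds than are shown below. What is called first, only, known or untested is meant among the compounds shown, and "the series" means these compounds.

In an ADME assay on HEK293 cells (Homo sapiens) for cytotoxicity, with a stated time of 6 h (a lower number here means that less compound is tolerated, a higher number that more compound is tolerated), compound 1 (`CCCCNc1nc(N)ncc1OCC`) gives > 25000 nM as a limit of the assay. Compound 2 (`CCCNc1nc(N)nc2ccccc12`) gives > 25000 nM as a limit too. Both compounds therefore stand at the same limit (the limit of > 25000 nM in this assay, at which 2 of the 2 values shown sit). Compound 3 (`CC(C)CCNc1nc(N)nc2ccccc12`) carries isopropyl in place of methyl on a saturated chain carbon, two bonds along the chain from a nitrogen on an aromatic ring. From compound 2 at > 25000 nM no step beyond the scatter is expected in this assay and another limit is likely. The estimated change is small (a step that the limit leaves unreadable from compound 2 to compound 3). For compound 3 the expected value is 28000 nM within an estimated range (14000 nM to 50000 nM).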

Compound 3, half-maximal cytotoxic concentration: > 25000 nM
Compound 3 ended at the assay's limit (the forecaster's own chance of this, stated with the estimate: 85%); the middle value is on the limit's open side.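

Compound 3 stands at a limit in this assay, so no step from compound 2 can be read: the limit of > 25000 nM in this assay, at which 3 of the 3 values shown sit.

The compounds shown leave open at what concentration any of them becomes cytotoxic, and whether isopentyl for propyl changes that concentration.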